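This account rests on a few compounds, and the source may have more. Where it says the series, first, only, none or still open, it means among the compounds named here.

Compound 1 `COc1ccc(-c2cc(/C=C/C(=O)c3ccc(N)cc3)[nH]n2)cc1`: 95%
Compound 2 `COc1cc(-c2cc(/C=C/C(=O)c3ccc(N)cc3)[nH]n2)cc(OC)c1OC`: 99%
Compound 3 `COc1ccc(C(=O)/C=C/c2cc(-c3cc(OC)c(OC)c(OC)c3)n[nH]2)cc1`: 91%

Of the compounds shown here, three built on one shared core have been measured in a functional assay on SF-268 cells (Homo sapiens) for cytotoxicity, read by sulforhodamine B assay, with a stated time of 48 h, tested at 0.01 uM; a lower number here means a stronger effect, a higher number a weaker effect of the compound at the concentration tested. Compound 2 gives 99%, the highest of the three numbers, though compound 1 with 95% and compound 3 with 91% both lie within the scatter of it, so no order among them can be claimed. Going by the values given here, the only step between two compounds that differ in a single place, methoxy in place of amino on an aromatic carbon, ran a number 8 percentage points lower from compound 2 to compound 3 (within the scatter). Compound 4 `COc1ccc(-c2cc(/C=C/C(=O)c3ccc(N)cc3)[nH]n2)cc1OC` has not yet been measured; it differs from compound 2 by hydrogen in place of methoxy on an aromatic carbon. Among the compounds with values here, no measured step removes a methoxy group from that ring, so the guidance is indirect: the one step seen stayed within the scatter, and the values of compound 1 and compound 2, which differ in methoxy groups on the same ring, also lie within the scatter of each other. Compound 4 is therefore expected to move a number 3 percentage points lower from compound 2 to compound 4 (within the scatter) in this assay, no step beyond the scatter. Compound 4 is estimated at 96%, between 85% and 104%.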

Compound 4, a percentage reported as activity, at one concentration (the size of the read-out at that concentration, not a potency): 100%
Compound 4: the middle estimate sits 4 percentage points below what was measured, and the stated range covers the measured number.
By their numbers in this assay, from the lowest: compounds 3, 1, 2 and 4 (each within the scatter of the next).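

In this assay, hydrogen in place of methoxy on this aromatic carbon, ortho to a methoxy group and meta to a large group, gave a number 1 percentage points higher from compound 2 to compound 4 (within the scatter). Approached from the other side, one further methoxy group on this ring gave a number 5 percentage points higher from compound 1 to compound 4 (within the scatter), so both single-place changes on this ring now stand within the scatter, where the earlier compounds offered only the change on the other aromatic ring. No information is available to explain this result.

The compounds shown leave open whether a hydroxy group, a chlorine atom or an ethoxy group at this position would give a step beyond the scatter. Going by these compounds alone, they also leave open whether the methoxy groups on this ring matter at all in this assay, since no step here separates the compounds.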